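From 2,5-dimethylphenyl to 4-chlorophenyl: one swap, one open value

The compounds below may be only part of what the source reports. "The series", "measured", "known", "first", "only" and "open" are said of these compounds alone.

Compound 1 `Cc1ccc(C)c(NC(=O)Nc2nc(Sc3c[nH]c4ccccc34)cc(N3CCCCC3)n2)c1` gives 25400 nM
Compound 2 `O=C(Nc1ccccc1)Nc1nc(Sc2c[nH]c3ccccc23)cc(N2CCCC2)n1` gives 21200 nM
Compound 3 `O=C(Nc1ccccc1)Nc1nc(Sc2c[nH]c3ccccc23)cc(N2CCN(Cc3ccccc3)CC2)n1` gives > 50000 nM

These three compounds were tested in a functional assay on A549 cells (Homo sapiens) for inhibition, with a stated time of 72 h; a higher number here means a weaker inhibitor, a lower number a stronger inhibitor. Within the data shown here, compound 1 and compound 2 lie within the usual scatter of each other, which places compound 1 level with the only other exact number available. For compound 3 the entry > 50000 nM is a limit of the assay and not a number.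

Compound 4 `O=C(Nc1ccc(Cl)cc1)Nc1nc(Sc2c[nH]c3ccccc23)cc(N2CCCCC2)n1` has not yet been measured. It differs from compound 1 by a single change (4-chlorophenyl in place of 2,5-dimethylphenyl on an amide-type nitrogen), with 4-chlorophenyl in place of 2,5-dimethylphenyl on an amide-type nitrogen. Among the measured compounds shown here, no measured pair shows this change alone. Compound 2 differs from compound 1 in more than one place, yet compound 2 still gives 21200 nM and stays within the scatter of compound 1. On that basis, no step beyond the scatter is expected in this assay. The estimated change a 1.4-fold lower number from compound 1 to compound 4 (0.15 log units; within the scatter) is small. For compound 4 the expected value is 18000 nM, with an estimated range of 6000 nM to 45000 nM.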

Compound 4, half-maximal inhibitory concentration: 18600 nM
Compound 4: middle estimate off by 1.0-fold (0.01 log units), on the low side; the range from low to high includes it.
By their numbers in this assay, from the lowest: compounds 4, 2 and 1 (each within the scatter of the next). At a limit, above all of these: compound 3.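

Among these compounds, this is the first pair that differs in one place only, and the swap on an amide-type nitrogen gives a 1.4-fold lower number from compound 1 to compound 4 (0.14 log units; within the scatter) in this assay. Among the compounds shown here, at this position, then, a phenyl ring carrying chlorine and one carrying methyl groups cannot be told apart in this measurement, which the earlier compounds could not show because each differed from the others in more than one place or lacked an exact number. Compound 3 gives only a limit and not a number: the limit of > 50000 nM in this assay, at which 1 of the 4 values shown sits.

On these data alone, whether a phenyl ring carrying an amine or a carboxylic acid at this position would give a step beyond the scatter remains open. Also open, as far as these compounds go, is what a longer alkyl chain in place of the phenyl ring on this nitrogen would do in this assay.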